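The source may report more compounds than this note shows. Statements on the series, on what has been measured and on what is new or still open speak of the compounds shown alone.

Measured compounds:
- compound 1, `Clc1ccc(-c2cc(-c3cccs3)nc(-c3ccccc3Cl)c2)o1`: 17200 nM
- compound 2, `Clc1ccc(-c2cc(-c3ccsc3)nc(-c3ccccn3)c2)o1`: 21900 nM
- compound 3, `Clc1ccc(-c2cc(-c3ccc(Cl)o3)cc(-c3ccsc3)n2)cc1`: 18700 nM

In a functional assay on K562 cells (Homo sapiens) for cytotoxicity, in the presence of a further agent that is not named here (on this read-out lower numbers stand for stronger inhibition and higher numbers for weaker inhibition), compound 3 gives 18700 nM, the second highest of the three numbers. Compound 1 gives 17200 nM and compound 2 gives 21900 nM; all three numbers sit within the scatter of one another, so no order among them can be read.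

Compound 4, `Clc1ccc(-c2cc(-c3ccsc3)nc(-c3ccccc3Cl)c2)o1`, has not yet been measured. It differs from compound 3 in one place: 2-chlorophenyl in place of 4-chlorophenyl on an aromatic carbon. Among the compounds with values here, the only measured single step, a 1.2-fold lower number from compound 2 to compound 3 (0.07 log units; within the scatter), concerns a different exchange at the same aromatic carbon and does not bear on moving the chlorine around the phenyl ring. Compound 1 also carries a 2-chlorophenyl group, but it differs from compound 3 in two places, so its value only shows that a 2-chlorophenyl-bearing compound gives a number in the same band as compound 3.

Within the data shown here, with every measured step within the scatter and no direct precedent for this exchange, compound 4 is expected to give a number close to that of compound 3, and the expected step of a 1.0-fold lower number from compound 3 to compound 4 (0.02 log units; within the scatter) lies within the scatter. The estimate for compound 4 is 18000 nM, with a range from 9000 nM to 36000 nM.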

Compound 4, half-maximal inhibitory concentration: 17200 nM
Estimate against measurement, compound 4: 1.0-fold (0.02 log units) above; the range from low to high includes it.
By their numbers in this assay, from the lowest: compounds 1, 4, 3 and 2 (each within the scatter of the next).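

In this assay, within the data shown here, shifting the chlorine from 4-chlorophenyl to 2-chlorophenyl on the aromatic carbon next to the ring nitrogen stays within the scatter (a 1.1-fold lower number from compound 3 to compound 4 (0.04 log units; within the scatter)), the first direct reading of where the chlorine sits on this phenyl ring. Among these compounds, the replacement of pyridin-2-yl by 2-chlorophenyl at this same carbon also stays within the scatter (a 1.3-fold lower number from compound 2 to compound 4 (0.10 log units; within the scatter)), and so does the exchange of thiophen-2-yl for thiophen-3-yl at another place on the core (no change at the digits printed from compound 1 to compound 4 (within the scatter)), the first single step to touch that thiophene link, so neither of the two places separates these compounds on this read-out. Nothing measured alongside these numbers offers an account of why they stay so close.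

Going by these compounds, all four compounds carry the 5-chlorofuran-2-yl group and all four numbers lie within the scatter of their neighbours, so it remains open whether any exchange at these places can move the number beyond the scatter at all. An amine or a carboxylic acid on the phenyl ring, a longer chain in its place, or a different group in place of the 5-chlorofuran-2-yl would be needed to test this.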